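The source may hold more compounds than are shown below. What is called first, only, known or untested is meant among the compounds shown, and "the series" means these compounds.

Measured in a functional assay on HOS cells (Homo sapiens) for inhibition, with a stated time of 72 h; a higher number here means a weaker inhibitor, a lower number a stronger inhibitor:
- compound 1 `NC1CCC(Nc2nc(NCc3ccc(-c4ccsc4)cc3)c3ncn(C4CCCC4)c3n2)CC1`: 120 nM
- compound 2 `NC1CCC(Nc2nc(NCc3ccc(-c4ccccc4)nc3)c3ncn(C4CCCC4)c3n2)CC1`: 206 nM
- compound 3 `NC1CCC(Nc2nc(NCc3ccc(-c4cccc(F)c4)nc3)c3ncn(C4CCCC4)c3n2)CC1`: 44 nM

Compound 3, at 44 nM, has the lowest number of the three, and the other two values lie beyond the scatter from it. The next compound, compound 4 `NC1CCC(Nc2nc(NCc3ccc(-c4cccs4)nc3)c3ncn(C4CCCC4)c3n2)CC1`, carries thiophen-2-yl in place of 3-fluorophenyl (thiophen-2-yl in place of 3-fluorophenyl on an aromatic carbon).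

Going by the values given here, two measured steps bear on this change. The first, a 4.7-fold lower number from compound 2 to compound 3 (0.67 log units; beyond the scatter), came from fluoro in place of hydrogen on an aromatic carbon, and compound 4 has no such fluoro. The second, a 1.7-fold higher number from compound 1 to compound 2 (0.23 log units; within the scatter), exchanged a larger piece that holds thiophen-3-yl for one that holds phenyl, and it stayed within the scatter. Neither step tests thiophen-2-yl directly, so the expectation is loose. Compound 4 is expected to land nearer compound 1 and compound 2 than compound 3, a modest move towards weaker inhibition in this assay. The expected step is a 2.7-fold higher number from compound 3 to compound 4 (0.44 log units; beyond the scatter). For compound 4 the estimated value is 120 nM, with an expected range of 45 nM to 320 nM.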

Compound 4, half-maximal inhibitory concentration: 32 nM
Compound 4: the middle estimate sits 3.8-fold (0.57 log units) above what was measured, and the stated range ends above it.
By their numbers in this assay, from the lowest: compounds 4 and 3 (each within the scatter of the next); then compounds 1 and 2 (each within the scatter of the next).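

In this assay, thiophen-2-yl in place of phenyl on this aromatic carbon, next to the ring nitrogen, gives a 6.4-fold lower number from compound 2 to compound 4 (0.81 log units; beyond the scatter), so the plain phenyl is not the only ring that can sit here, and swapping it for a smaller sulfur-containing ring lowers the number clearly. The exchange of 3-fluorophenyl for thiophen-2-yl gives a 1.4-fold lower number from compound 3 to compound 4 (0.14 log units; within the scatter), so these two groups cannot be told apart in this assay, although one has a fluoro on a six-membered ring and the other a sulfur in a five-membered ring. The wider exchange gives a 3.8-fold lower number from compound 1 to compound 4 (0.57 log units; beyond the scatter), but it alters the whole piece at once, so it assigns the gain to no single atom.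

No measurement here explains the gain from either group. Still open, from the compounds shown here alone, is whether furan-2-yl at this position, or an amine or a methyl on the thiophene ring, would hold this level.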